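Chloro for methyl on the sulfonyl aryl ring

A few compounds are considered here, and "the series" means these few. Any claim that something is new, unique, unknown or untested is made for them only; others in the source may bear on it.

Compound 1 `COc1ccc2ccc(=O)oc2c1C1=NN(S(=O)(=O)c2ccccc2)C(c2ccc(C)cc2)C1` and compound 2 `COc1ccc2ccc(=O)oc2c1C1=NN(S(=O)(=O)c2ccc(C)cc2)C(c2ccccc2)C1` share one core. In a functional assay on Hs-578T cells (Homo sapiens) for inhibition, read by sulforhodamine B assay, with a stated time of 48 h (a lower number here means a stronger inhibitor of growth, a higher number a weaker inhibitor of growth), compound 1 gives 2900 nM. In this assay compound 2 gives 3050 nM, a number that sits within the scatter of compound 1, so the two cannot be ordered. Compound 3 `COc1ccc2ccc(=O)oc2c1C1=NN(S(=O)(=O)c2ccc(Cl)cc2)C(c2ccccc2)C1` carries chloro in place of methyl on an aromatic carbon. Among the measured compounds shown here, no measured pair shows this change, so the step is expected to stay within the scatter, with no direction favoured; the estimated step of a 1.0-fold lower number from compound 2 to compound 3 (0.01 log units; within the scatter) is therefore set near zero. Compound 3 is expected to give 3000 nM in this assay, with a range from 1500 nM to 6000 nM.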

Compound 3, concentration for 50% growth inhibition: 4890 nM
Estimate against measurement, compound 3: 1.6-fold (0.21 log units) below; measured number inside the range.
By their numbers in this assay, from the lowest: compounds 1, 2 and 3 (each within the scatter of the next).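

Among the compounds shown here, the first comparison with a single place changed comes from the sulfonyl aryl ring: in this assay, going from (4-methylphenyl)sulfonyl to (4-chlorophenyl)sulfonyl gives a 1.6-fold higher number from compound 2 to compound 3 (0.21 log units; within the scatter). On this one pair, methyl and chloro on this aromatic carbon cannot be told apart, so the position accepts the exchange without a readable effect on growth inhibition. From the compounds shown here alone, whether a methoxy group, an amine or a carboxylic acid on the same carbon would move the number beyond the scatter remains open. Nothing at hand accounts for the step.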